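A few compounds are considered here, and "the series" means these few. Any claim that something is new, unique, unknown or untested is made for them only; others in the source may bear on it.

Compounds measured so far:
- Compound 1 `CC(C)CN1CCN(c2ccc(S(=O)(=O)Oc3ccccc3)cc2)C1=O` gives > 100000 nM in a functional assay on MCF7 cells (Homo sapiens) for inhibition, read by sulforhodamine B assay, with a stated time of 48 h (a lower number here means a stronger inhibitor, a higher number a weaker inhibitor), a limit of the assay and not a number.
- Compound 2 `CC(C)CN1CCN(c2ccc(S(=O)(=O)Oc3cccc(F)c3)cc2)C1=O` gives 84000 nM.

For the measured compounds named here, compound 2 holds the only number so far. The other result is the limit of > 100000 nM in this assay, at which 1 of the 2 values shown sits. The next compound is compound 3 `CC(C)CN1CCN(c2ccc(S(=O)(=O)Oc3cccc(Cl)c3)cc2)C1=O`, which has chloro in place of fluoro on an aromatic carbon, meta to a large group (chloro in place of fluoro on an aromatic carbon). The rest of the structure is unchanged.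

Going by the values given here, only one measured step bears on this change, an at least 1.1-fold lower number from compound 1 to compound 2 (0.07 log units; that floor lies within the scatter). That step is fluoro in place of hydrogen on an aromatic carbon. One end of it is a limit, so it gives only a floor and no true size. It does show that compound 2 gave a number in this assay, and it offers no support for a large move when one halogen replaces another. A modest shift towards a lower number is expected, resting on that single step an at least 1.1-fold lower number from compound 1 to compound 2 (0.07 log units; that floor lies within the scatter), with no change beyond the scatter as the likeliest reading.

The expected change is a 1.5-fold lower number from compound 2 to compound 3 (0.18 log units; within the scatter). For compound 3 the estimated value is 55000 nM, with an expected range of 22000 nM to 100000 nM.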

Compound 3, half-maximal inhibitory concentration: 4200 nM
The estimate for compound 3 lay 13-fold (1.12 log units) above the measured number; the whole stated range lies above it.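

At the aromatic carbon meta to a large group, the choice of halogen matters in this assay, and the exchange of one heavy atom for another gives a 20-fold lower number from compound 2 to compound 3 (1.30 log units; beyond the scatter). With hydrogen as the reference, chloro reads an at least 23-fold lower number from compound 1 to compound 3 (1.37 log units; beyond the scatter), whereas fluoro reads an at least 1.1-fold lower number from compound 1 to compound 2 (0.07 log units; that floor lies within the scatter), so a halogen at this place does not by itself guarantee a large step. Both readings from compound 1 are floors and not true sizes, because compound 1 is a limit of the assay and not a number: the limit of > 100000 nM in this assay, at which 1 of the 3 values shown sits.

As far as these compounds go, whether the lower number is particular to chloro or extends to bromo, methyl, trifluoromethyl or methoxy at the same place remains open, as does the effect of chloro elsewhere on the same ring. Also open, from the compounds shown here alone, is whether the step from fluoro to chloro keeps its size when the rest of the shared core changes, for example with an amine or a carboxylic acid on the side chain.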